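The source may report more compounds than this note shows. Statements on the series, on what has been measured and on what is new or still open speak of the compounds shown alone.

The measured compounds, with their values in a functional assay (spleen, spleen) for activation, with Mus musculus as the target; on this read-out lower numbers stand for an effect already at smaller amounts and higher numbers for an effect only at larger amounts of compound:

- Compound 1, `CNc1nc(N)c2nc(O)n(Cc3ccccc3)c2n1`: 1 uM
- Compound 2, `Nc1ncnc2c1nc(S)n2Cc1ccccc1`: 10 uM

Compound 1 stands at the lowest of the two numbers in this assay. Compound 2 sits at a higher number, and the two values show a gap that lies beyond the usual scatter of repeated measurements, so compound 1 is the one that acts at the smaller amount.

Compound 3, `CSc1nc(N)c2nc(O)n(Cc3ccccc3)c2n1`, has not yet been measured. It is built from compound 1 by a single change: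

methylsulfanyl in place of methylamino on an aromatic carbon

For the measured compounds named here, no pair of measured compounds differs in this one place, so there is no measured step to lean on; the only anchors are the value of compound 1 and the nature of the exchange, in which a group carrying a hydrogen-bond donor gives way to one carrying none. The expected step from compound 1 to compound 3 in this assay is a 3.0-fold higher number from compound 1 to compound 3 (0.48 log units; beyond the scatter), a modest shift toward a higher number. Compound 3 is therefore estimated at 3 uM, with a likely range from 0.7 uM to 15 uM.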

Compound 3, minimum effective concentration: 0.1 uM
Beside the measured number, compound 3's estimate is 30-fold (1.48 log units) above it, and the stated range ends above it.
By their numbers in this assay, from the lowest: compound 3; then compound 1; then compound 2.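

In this assay, putting methylsulfanyl in place of methylamino on this aromatic carbon, between two ring nitrogen atoms, gives a 10-fold lower number from compound 1 to compound 3 (1.00 log units; beyond the scatter) and so moves the read-out toward effect at smaller amounts. The group that leaves has 1 hydrogen-bond donor and the group that enters has 0 hydrogen-bond donors, so in this pair the donor at this position is not needed for activity, and its loss goes together with a lower number. This pair is the only measured view of this position, as compound 2 differs from compound 1 in more than one place, and no measurement available here accounts for the size or direction of the step.

Going by these compounds, with one pair, it remains open whether the lower number follows the sulfur atom, the missing donor or something else about the exchange. Methoxy, which keeps the shape of the group but carries oxygen in place of sulfur, would help separate these readings, while ethylsulfanyl or a longer sulfur-linked chain would show how much size this position tolerates.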